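Nitronyl nitroxide amino acid conjugates: PC-12 series notes

The compounds below may be only part of what the source reports. "The series", "measured", "known", "first", "only" and "open" are said of these compounds alone.

Measured so far:
compound 1 `CC1(C)N(O)C(c2ccc(OCCNC(=O)C[C@H](N)C(=O)O)cc2)=[N+]([O-])C1(C)C` 48600 nM
compound 2 `CC(C)(C)OC(=O)N[C@@H](CCC(=O)NCCOc1ccc(C2=[N+]([O-])C(C)(C)C(C)(C)N2O)cc1)C(=O)O` 49900 nM

In a functional assay on PC-12 cells (Rattus norvegicus) for inhibition, read by MTT assay (on this read-out lower numbers stand for an effect already at smaller amounts and higher numbers for an effect only at larger amounts of compound), compound 1 gives 48600 nM and compound 2 gives 49900 nM. On this assay compound 2 and compound 1 are indistinguishable within the scatter. Compound 3 `CC1(C)N(O)C(c2ccc(OCCNC(=O)CC[C@H](N)C(=O)O)cc2)=[N+]([O-])C1(C)C` is not yet measured. It differs from compound 2 by hydrogen in place of tert-butoxycarbonyl on an amine nitrogen. With compound 1 already carrying a free amine at 48600 nM, the step from compound 2 to compound 3 is expected to be none beyond the scatter, a 1.0-fold lower number from compound 2 to compound 3 (0.01 log units; within the scatter). Compound 3 is estimated at 49000 nM, within 20000 nM to 120000 nM.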

Compound 3, half-maximal effective concentration: 49600 nM
Beside the measured number, compound 3's estimate is 1.0-fold (0.01 log units) below it; low and high end bracket the measured number.
By their numbers in this assay, from the lowest: compounds 1, 3 and 2 (each within the scatter of the next).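

In this assay, hydrogen in place of tert-butoxycarbonyl on this amine nitrogen gives a 1.0-fold lower number from compound 2 to compound 3 (0.00 log units; within the scatter), so the read-out at this position does not separate the free amine from its protected form. The chain change, 2-amino-2-carboxyethyl in place of amino(carboxy)methyl, gives a 1.0-fold higher number from compound 1 to compound 3 (0.01 log units; within the scatter), so this one-step difference in chain length is not resolved either. No available evidence bears on this result.

As far as these compounds go, whether a methyl ester in place of the carboxylic acid, or a longer chain, would move the number beyond the scatter remains open.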